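From 2-nitrophenyl to 4-aminophenyl on a shared core

This account rests on a few compounds, and the source may have more. Where it says the series, first, only, none or still open, it means among the compounds named here.

In a functional assay on SW480 cells (Homo sapiens) for cytotoxicity, read by MTT assay, with a stated time of 48 h (on this read-out lower numbers stand for stronger inhibition and higher numbers for weaker inhibition), compound 2 (`COc1cc(C(=O)c2cn(-c3cccc(N)c3)cc2-c2ccccc2[N+](=O)[O-])cc(OC)c1OC`) gives 164 nM, level within the scatter with compound 1 (`COc1cc(C(=O)c2cn(-c3cccc(N)c3)cc2-c2ccccc2F)cc(OC)c1OC`) at 162 nM. Compound 3 (`COc1cc(C(=O)c2cn(-c3cccc(N)c3)cc2-c2ccc(N)cc2)cc(OC)c1OC`) has 4-aminophenyl in place of 2-nitrophenyl on an aromatic carbon. Among the compounds with values here, the only measured step that bears on this change is a 1.0-fold higher number from compound 1 to compound 2 (0.01 log units; within the scatter), for nitro in place of fluoro. Within the data shown here, no measured compound carries 4-aminophenyl, so no step beyond the scatter and no direction is expected in this assay. The expected step is a 1.1-fold lower number from compound 2 to compound 3 (0.04 log units; within the scatter). Compound 3 is estimated at 150 nM, with an expected range from 30 nM to 750 nM.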

Compound 3, half-maximal inhibitory concentration: 48 nM
Beside the measured number, compound 3's estimate is 3.1-fold (0.49 log units) above it; the measured number falls inside the stated range.
By their numbers in this assay, from the lowest: compound 3; then compounds 1 and 2 (each within the scatter of the next).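

The position on the five-membered aromatic ring, which had shown no difference between 2-fluorophenyl and 2-nitrophenyl, does respond to the group it carries: this assay gives a 3.4-fold lower number from compound 2 to compound 3 (0.53 log units; beyond the scatter) and a 3.4-fold lower number from compound 1 to compound 3 (0.53 log units; beyond the scatter) when 4-aminophenyl enters. Within the data shown here, both steps are modest, but they are the first beyond the scatter at this position. Nothing available explains them.

The change alters both the substituent and where it sits on the phenyl ring, so the two remain unseparated. A 2-aminophenyl or 4-nitrophenyl group at this position would tell them apart.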